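The source may hold more compounds than are shown below. What is called first, only, known or untested is meant among the compounds shown, and "the series" means these compounds.

Of the compounds shown here, three sharing one core have been measured in a functional assay on MCF7 cells (Homo sapiens) for inhibition, read by MTT assay, with a stated time of 72 h; a lower number here means a stronger inhibitor, a higher number a weaker inhibitor. Compound 1 (`Cc1cc(Nc2cc(-c3ccccc3)[nH]n2)n2nc(SCc3c(Cl)cccc3Cl)nc2n1`), with a 2,6-dichlorophenyl group on a saturated chain carbon bound to a sulfur, gives 3230 nM. Compound 2 (`Cc1cc(Nc2cc(-c3ccccc3)[nH]n2)n2nc(SCc3csc4ccccc34)nc2n1`), with 1-benzothiophen-3-yl in that place, gives 3470 nM, and the step is a 1.1-fold higher number from compound 1 to compound 2 (0.03 log units; within the scatter). Compound 3 (`CCCSc1nc2nc(C)cc(Nc3cc(-c4ccccc4)[nH]n3)n2n1`) carries propylsulfanyl and reads > 50000 nM, which is a limit of the assay and not a number. The steps to it are large: an at least 15-fold higher number from compound 1 to compound 3 (1.18 log units; beyond the scatter) and an at least 14-fold higher number from compound 2 to compound 3 (1.15 log units; beyond the scatter).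

The next structure is compound 4 (`Cc1cc(Nc2cc(-c3ccccc3)[nH]n2)n2ncnc2n1`), and the change is hydrogen in place of propylsulfanyl on an aromatic carbon. Within the data shown here, no measured step removes the sulfur, so the evidence is indirect. The two large steps show that, among these three compounds, the measurable numbers go with the aromatic groups, and compound 4 has none. The step of an at least 14-fold higher number from compound 2 to compound 3 (1.15 log units; beyond the scatter) therefore gives no reason to expect a gain from losing the rest of the chain. The expected step is a step that the limit leaves unreadable from compound 3 to compound 4, meaning no clear change is expected, and the reading may again be only a limit. For compound 4 the estimated value is 60000 nM, with an expected range of 25000 nM to 150000 nM.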

Compound 4, half-maximal inhibitory concentration: > 50000 nM
Compound 4 was reported as a limit; the forecaster's own chance of this, stated with the estimate: 75%; the middle value is on the limit's open side.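

Taking away the whole substituent, so that hydrogen stands on the aromatic carbon between two ring nitrogen atoms, leaves the shared core without a measurable number in this assay and the steps from the two aromatic compounds are large (an at least 14-fold higher number from compound 2 to compound 4 (1.15 log units; beyond the scatter) and an at least 15-fold higher number from compound 1 to compound 4 (1.18 log units; beyond the scatter)). Among these four compounds, measured numbers appear only with the (2,6-dichlorobenzyl)sulfanyl and ((1-benzothiophen-3-yl)methyl)sulfanyl groups, while neither the core with hydrogen in compound 4 nor the sulfur with a propyl chain in compound 3 gives one. The step from compound 3 to compound 4 cannot be read, since both compounds rest on the same limit and no difference between propylsulfanyl and hydrogen can be seen: the limit of > 50000 nM in this assay, at which 2 of the 4 values shown sit.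

The compounds shown leave open whether a plain benzylsulfanyl group, an amine or a carboxylic acid at this place would give a measurable number. Among these compounds, they also leave open whether the sulfur itself matters, since no compound here joins an aromatic group to this carbon through an oxygen atom or an amine nitrogen.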